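Hexyl extension of the acetamido chain in a macrolide series

A few compounds are considered here, and "the series" means these few. Any claim that something is new, unique, unknown or untested is made for them only; others in the source may bear on it.

Three macrolides have been measured in a physicochemical assay for lipophilicity, read by HPLC, measured as chromatographic lipophilicity, at pH 7.4; on this read-out lower numbers stand for lower lipophilicity and higher numbers for higher lipophilicity. Compound 1 `CC[C@H]1OC(=O)[C@H](C)[C@@H](O[C@H]2C[C@@](C)(OC)[C@@H](O)[C@H](C)O2)[C@H](C)[C@@H](O[C@@H]2O[C@H](C)C[C@H](N(C)C)[C@H]2O)[C@](C)(O)C[C@@H](C)CN(CCCNC(=O)C2CCC2)[C@H](C)[C@@H](O)[C@]1(C)O` gives 2.31. Compound 2 `CCC(=O)NCCCO[C@H]1[C@H](O[C@@H]2[C@@H](C)[C@H](O[C@H]3C[C@@](C)(OC)[C@@H](O)[C@H](C)O3)[C@@H](C)C(=O)O[C@H](CC)[C@@](C)(O)[C@H](O)[C@@H](C)N(C)C[C@H](C)C[C@@]2(C)O)O[C@H](C)C[C@@H]1N(C)C` gives 2.7 in this assay. Compound 3 `CC[C@H]1OC(=O)[C@H](C)[C@@H](O[C@H]2C[C@@](C)(OC)[C@@H](O)[C@H](C)O2)[C@H](C)[C@@H](O[C@@H]2O[C@H](C)C[C@H](N(C)C)[C@H]2O)[C@](C)(OC)C[C@@H](C)C(=O)[C@H](C)[C@@H](OCCCNC(C)=O)[C@]1(C)O` gives 2.72 in this assay; this value and that of compound 2 lie within the scatter of each other, while compound 1 sits lower than compound 3 by a gap beyond the scatter. Compound 4 `CCCCCCCC(=O)NCCCO[C@@H]1[C@@H](C)C(=O)[C@H](C)C[C@@](C)(OC)[C@H](O[C@@H]2O[C@H](C)C[C@H](N(C)C)[C@H]2O)[C@@H](C)[C@H](O[C@H]2C[C@@](C)(OC)[C@@H](O)[C@H](C)O2)[C@@H](C)C(=O)O[C@H](CC)[C@@]1(C)O` carries the change hexyl in place of hydrogen on a saturated chain carbon bound to a carbonyl carbon relative to compound 3. Among the compounds with values here, no measured pair shows this kind of step, so the size rests on the six added carbons alone. Compound 4 is expected to show a clear rise in this assay, a step of a number 1.48 log units higher from compound 3 to compound 4 (beyond the scatter). The estimate for compound 4 is 4.2, with a range from 3.5 to 5.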

Compound 4, distribution coefficient: 5.07
Estimate against measurement, compound 4: 0.87 log units below, and the stated range ends below it.
By their numbers in this assay, from the lowest: compound 1; then compounds 2 and 3 (each within the scatter of the next); then compound 4.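

In this assay, within the data shown here, hexyl in place of hydrogen on a saturated chain carbon bound to a carbonyl carbon gives a number 2.35 log units higher from compound 3 to compound 4 (beyond the scatter) and provides the first single-place step. The read-out therefore responds strongly at this position to the change from acetamido to (heptylcarbonyl)amino, which compounds 1, 2 and 3 could not show. No supporting measurement accounts for the size of this step. From the compounds shown here alone, one step gives no trend with chain length, so the course of the rise remains open. A shorter butyl chain, or an amine or carboxylic acid at the end of the chain, would test how the read-out responds at this position.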